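Bromo added to a dimethoxy cinnamoyl indole series

This account rests on a few compounds, and the source may have more. Where it says the series, first, only, none or still open, it means among the compounds named here.

Compound 1, `COc1ccc(/C(Cl)=C/C=C(\C#N)C(=O)c2c[nH]c3ccc(Br)cc23)cc1`: > 100000 nM
Compound 2, `COc1ccc(/C(Cl)=C/C=C(\C#N)C(=O)c2c[nH]c3ccccc23)cc1OC`: > 100000 nM

Compound 1 carries a bromo on its fused ring and a single methoxy on the pendant ring. In a functional assay on MCF7 cells (Homo sapiens) for cytotoxicity, read by sulforhodamine B assay, with a stated time of 48 h (a lower number here means a stronger inhibitor of growth, a higher number a weaker inhibitor of growth), compound 1 returns only a limit, > 100000 nM, and not a number. Compound 2 carries two methoxy groups on the pendant ring and no bromo. In this assay compound 2 likewise returns only a limit, > 100000 nM, and not a number. Both measured values rest at the limit of > 100000 nM in this assay, at which 2 of the 2 values shown sit. Going by the values given here, compound 2 thus stands at the limit of this assay, and no step between measured compounds is available.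

Compound 3, `COc1ccc(/C(Cl)=C/C=C(\C#N)C(=O)c2c[nH]c3ccc(Br)cc23)cc1OC`, combines the two features: it differs from compound 2 by bromo in place of hydrogen on an aromatic carbon. Since compound 1, which already carries this bromo, stays at its limit, compound 3 is expected to show no step beyond the scatter, in either direction. Compound 3 is expected to give 100000 nM in this assay, within 30000 nM to 300000 nM. The expected step of a number no higher from compound 2 to compound 3 (the limit leaves the size open) is therefore estimated as no change.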

Compound 3, concentration for total growth inhibition: > 100000 nM
Compound 3: a limit, no number; the forecaster's own chance of this, stated with the estimate: 80%; the middle value lies on the limit itself.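

In this assay compound 3 gives > 100000 nM as a limit and not a number. The steps to compound 3 from compound 1 and from compound 2 cannot be read, as all three compounds rest at one limit: the limit of > 100000 nM in this assay, at which 3 of the 3 values shown sit.

The compounds shown leave open whether bromo or methoxy in place of hydrogen changes growth inhibition in this assay at all.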